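This account rests on a few compounds, and the source may have more. Where it says the series, first, only, none or still open, it means among the compounds named here.

The series shares the core of compound 1 `CC(C)(C)N(NC(=O)c1ccccc1F)C(=O)c1ccccc1Cl` and varies only the aryl group on one carbonyl carbon. Among the measured compounds shown here, in an assay on cells for agonist activity at ecdysone receptor (Bombyx mori), read by a luciferase reporter, with a stated time of 24 h (a higher number here means that more compound is needed for the effect, a lower number that less compound is needed), compound 1 gives 51.3 nM, the second highest of the three numbers measured so far. Compound 2 `CC(C)(C)N(NC(=O)c1cccc(Br)c1)C(=O)c1ccccc1Cl` gives 191 nM and compound 3 `Cc1ccc(C(=O)NN(C(=O)c2ccccc2Cl)C(C)(C)C)cc1` gives 18.6 nM. The measured steps are a 3.7-fold higher number from compound 1 to compound 2 (0.57 log units; beyond the scatter), a 2.8-fold lower number from compound 1 to compound 3 (0.44 log units; beyond the scatter) and a 10-fold lower number from compound 2 to compound 3 (1.01 log units; beyond the scatter), so among these three compounds the 4-methylphenyl group of compound 3 goes with the lowest number.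

Compound 4 `COc1ccc(C(=O)NN(C(=O)c2ccccc2Cl)C(C)(C)C)cc1` differs from compound 1 by 4-methoxyphenyl in place of 2-fluorophenyl on a carbonyl carbon. For the measured compounds named here, no compound with a methoxy group has been measured, so the closest guide is the step in which 4-methylphenyl enters, a 2.8-fold lower number from compound 1 to compound 3 (0.44 log units; beyond the scatter). Given that step and the closer resemblance of 4-methoxyphenyl to 4-methylphenyl than to 3-bromophenyl, a modest step to a lower number is expected, a 2.1-fold lower number from compound 1 to compound 4 (0.31 log units; beyond the scatter), with the range kept wide since the methoxy group itself is untested. Compound 4 is therefore estimated at 25 nM, within 8 nM to 80 nM.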

Compound 4, half-maximal effective concentration: 51.3 nM
Beside the measured number, compound 4's estimate is 2.1-fold (0.31 log units) below it; the measured number falls inside the stated range.
By their numbers in this assay, from the lowest: compound 3; then compounds 1 and 4 (each within the scatter of the next); then compound 2.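

In this assay the first read on a methoxy group here is a 2.8-fold higher number from compound 3 to compound 4 (0.44 log units; beyond the scatter) and so 4-methoxyphenyl does not share the lower number that goes with 4-methylphenyl, and the two groups are not interchangeable on this carbonyl carbon. Against 2-fluorophenyl the result is no change at the digits printed from compound 1 to compound 4 (within the scatter) and so these two differently substituted aryl groups cannot be told apart in this read-out, while a 3.7-fold lower number from compound 2 to compound 4 (0.57 log units; beyond the scatter) leaves 3-bromophenyl alone with the highest number of the four compounds. No measurement shown accounts for any of these steps.

Still open, from the compounds shown here alone, is how a 4-ethylphenyl, 4-aminophenyl or 4-carboxyphenyl group on the same carbonyl carbon would compare with 4-methylphenyl and 4-methoxyphenyl. Also open, going by these compounds, is whether the gap between those two groups persists when the rest of the shared core changes.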